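Working notes: aryl swap on the longer-chain pair

A few compounds are considered here, and "the series" means these few. Any claim that something is new, unique, unknown or untested is made for them only; others in the source may bear on it.

Compound 1 `CCCCCCCCn1cc(/C=C/C(=O)c2ccc(NC(=O)CN3CCN(c4ccccc4F)CC3)cc2)nn1` and compound 2 `CCCCCCCCn1cc(/C=C/C(=O)c2ccc(NC(=O)CN3CCN(c4ccc([N+](=O)[O-])cc4)CC3)cc2)nn1` share a core with the shorter chain; compound 3 `CCCCCCCCCCn1cc(/C=C/C(=O)c2ccc(NC(=O)CN3CCN(c4ccc([N+](=O)[O-])cc4)CC3)cc2)nn1` and the unmeasured compound 4 `CCCCCCCCCCn1cc(/C=C/C(=O)c2ccc(NC(=O)CN3CCN(c4ccccc4F)CC3)cc2)nn1` carry the extended chain. In a functional assay on A549 cells (Homo sapiens) for inhibition, read by MTT assay (on this read-out lower numbers stand for stronger inhibition and higher numbers for weaker inhibition), compound 1 gives 47100 nM and compound 2 gives 45400 nM. The two differ by 2-fluorophenyl in place of 4-nitrophenyl on an amine nitrogen in a ring, and the step is a 1.0-fold higher number from compound 2 to compound 1 (0.02 log units; within the scatter). Compound 3 gives 64500 nM in this assay; it differs from compound 2 by ethyl in place of hydrogen on a saturated chain carbon, eight bonds along the chain from an aromatic nitrogen, with a step of a 1.4-fold higher number from compound 2 to compound 3 (0.15 log units; within the scatter). Going by the values given here, compound 4 differs from compound 3 by 2-fluorophenyl in place of 4-nitrophenyl on an amine nitrogen in a ring, the same change as the one from compound 2 to compound 1 and at the same place. Because the earlier step of a 1.0-fold higher number from compound 2 to compound 1 (0.02 log units; within the scatter) stayed within the scatter, the step from compound 3 to compound 4 is expected to be a 1.0-fold lower number from compound 3 to compound 4 (0.02 log units; within the scatter). Compound 4 is therefore estimated at 62000 nM in this assay, with a range from 30000 nM to 125000 nM. Among the compounds with values here, only three measured compounds support this, so the estimate rests on a single prior occurrence of the change.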

Compound 4, half-maximal inhibitory concentration: 57000 nM
Compound 4: the middle estimate sits 1.1-fold (0.04 log units) above what was measured; measured number inside the range.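

In this assay, the change to 2-fluorophenyl in place of 4-nitrophenyl on the core of compound 3 gives a 1.1-fold lower number from compound 3 to compound 4 (0.05 log units; within the scatter), and it matches the earlier step on the other core: the same change on two cores in this assay, a 1.0-fold higher number (0.02 log units; within the scatter) from compound 2 to compound 1 and a 1.1-fold lower number (0.05 log units; within the scatter) from compound 3 to compound 4, 1.2-fold (0.07 log units) apart, within the scatter of two such steps. The addition of ethyl in place of hydrogen on the saturated chain, now read on the 2-fluorophenyl pair, gives a 1.2-fold higher number from compound 1 to compound 4 (0.08 log units; within the scatter), and it also matches its earlier counterpart: the same change on two cores in this assay, a 1.4-fold higher number (0.15 log units; within the scatter) from compound 2 to compound 3 and a 1.2-fold higher number (0.08 log units; within the scatter) from compound 1 to compound 4, 1.2-fold (0.07 log units) apart, within the scatter of two such steps. Going by these compounds alone, each change therefore carries from one core to the other in this four-compound square, but all of these steps lie within the scatter, so this shows only that neither change produced a step beyond the scatter on either core, not that a larger step would carry over in the same way.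

The compounds shown leave open whether a much shorter chain, or a chain ending in a carboxylic acid or an amine, would give a step beyond the scatter. On these data alone, it also remains open whether unsubstituted phenyl or a pyridine on the ring amine nitrogen would do so, and whether such a step would carry between cores.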